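The compounds below may be only part of what the source reports. "The series", "measured", "known", "first", "only" and "open" are said of these compounds alone.

Measured in a functional assay on PC-3 cells (Homo sapiens) for cytotoxicity, read by WST assay, with a stated time of 72 h; on this read-out higher numbers stand for weaker inhibition and lower numbers for stronger inhibition:
compound 1 `O=C1Nc2c(ccc(F)c2F)C1(c1ccc(O)cc1)c1ccc(F)cc1` gives 8.6 nM
compound 2 `O=C1Nc2c(ccc(F)c2F)C1(c1ccc(O)cc1)C1CCCCCC1` gives 12 nM
compound 3 `O=C1Nc2ccccc2C1(c1ccc(O)cc1)c1ccc(F)cc1` gives only a limit, > 1000 nM

Within the data shown here, the one measured step is cycloheptyl in place of 4-fluorophenyl on a saturated ring carbon; it made a 1.4-fold higher number from compound 1 to compound 2 (0.14 log units; within the scatter). For compound 3 the read-out stops at a limit, (the limit of > 1000 nM in this assay, at which 1 of the 3 values shown sits), so no number is known for it. The difference between the core of compound 1 and the core of compound 3 is not broken down here.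

Compound 4 `O=C1Nc2ccccc2C1(c1ccc(O)cc1)C1CCCCCC1` is not yet measured in this assay . Relative to compound 3 it carries cycloheptyl in place of 4-fluorophenyl on a saturated ring carbon, the same change as the one from compound 1 to compound 2. Because a 1.4-fold higher number from compound 1 to compound 2 (0.14 log units; within the scatter) lies within the scatter, compound 4 is expected to stay close to compound 3 in this assay . The expected step is a step that the limit leaves unreadable from compound 3 to compound 4. For compound 4 the estimate is 2000 nM, most likely again reported only as a limit.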

Compound 4, half-maximal inhibitory concentration: > 1000 nM
Compound 4: only a limit was reported; the forecaster's own chance of this, stated with the estimate: 75%; the middle value does not contradict the limit.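

Compound 3 and compound 4 both stop at a limit, so no step between them can be read: the limit of > 1000 nM in this assay, at which 2 of the 4 values shown sit.

Still open, from the compounds shown here alone, is whether exchanging 4-fluorophenyl for cycloheptyl changes anything on the core shared by compound 3 and compound 4.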